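Removing the nitrogen methyl from compound 2

The compounds below may be only part of what the source reports. "The series", "measured", "known", "first", "only" and "open" are said of these compounds alone.

Of the compounds shown here, three sharing one core have numbers so far in a functional assay on WRL68 cells (Homo sapiens) for cytotoxicity, read by MTT assay, with stated times of 6 h and 48 h (a higher number here means a weaker inhibitor, a lower number a stronger inhibitor), for this series. There, compound 1 `Cn1c(/C=C/C(=O)c2ccc[nH]2)cc(Br)c1Br` gives 2110 nM and compound 2 `COc1ccc(C(=O)/C=C/c2cc(Br)c(Br)n2C)c(OC)c1` gives 640 nM as the lowest of the three numbers, while compound 3 `Cn1c(/C=C/C(=O)c2ccc(Cl)cc2Cl)cc(Br)c1Br` gives 14700 nM as the highest. The gaps from compound 2 to each of the other two lie beyond the usual scatter, which makes compound 2 the strongest inhibitor of this small set.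

The unmeasured compound 4 `COc1ccc(C(=O)/C=C/c2cc(Br)c(Br)[nH]2)c(OC)c1` differs from compound 2 in one place: hydrogen in place of methyl on an aromatic nitrogen with hydrogen in place of methyl on an aromatic nitrogen. Going by the values given here, all three measured compounds carry that methyl and differ from one another in the group on the carbonyl, so no measured pair shows what its removal does. Compound 4 keeps the carbonyl group of compound 2 at 640 nM in this set, so its number is expected to stay fairly close. The estimate is a 1.4-fold higher number from compound 2 to compound 4 (0.15 log units; within the scatter) as a small move toward weaker inhibition, and it may not leave the scatter. For compound 4 the estimated value is 900 nM with an expected range of 280 nM to 3000 nM in this measurement.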

Compound 4, half-maximal inhibitory concentration: 9220 nM
Estimate against measurement, compound 4: 10-fold (1.01 log units) below; measured number outside the range, above it.
By their numbers in this assay, from the lowest: compound 2; then compound 1; then compounds 4 and 3 (each within the scatter of the next).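

Going by these compounds alone, the methyl on the aromatic nitrogen is the first place where a single change can be read. In this assay, hydrogen in place of methyl gives a 14-fold higher number from compound 2 to compound 4 (1.16 log units; beyond the scatter), a large step toward weaker inhibition with the carbonyl group held constant, so this position strongly affects the number in this pair. The earlier compounds all carried the methyl and differed only in the group on the carbonyl, so they could not show that the methyl on the nitrogen matters at all, and nothing available accounts for the size of this step.

On these data alone, whether an ethyl group, a longer chain or a 2-hydroxyethyl group on the aromatic nitrogen would keep the number near that of compound 2 stays open. Also open, as far as these compounds go, is whether removing the methyl brings a step of similar size in compound 1 and compound 3, which carry other groups on the carbonyl, since this single pair cannot establish a pattern across the series.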